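Compound 3 to compound 4: an exchange on oxygen

The compounds below may be only part of what the source reports. "The series", "measured", "known", "first", "only" and "open" are said of these compounds alone.

Compound 1 `O=C(O)CCCCCCC(=O)Nc1ccc(C2=C(c3ccc(O)cc3)C3CC(S(=O)(=O)Oc4cccc5ccccc45)C2O3)cc1`: 48600 nM
Compound 2 `Cc1ccc(OS(=O)(=O)C2CC3OC2C(c2ccc(NC(=O)CCCCCCC(=O)O)cc2)=C3c2ccc(O)cc2)cc1`: 80800 nM
Compound 3 `O=C(O)CCCCCCC(=O)Nc1ccc(C2=C(c3ccc(O)cc3)C3CC(S(=O)(=O)Oc4ccc(C(F)(F)F)cc4)C2O3)cc1`: 77000 nM

In a functional assay on DU-145 cells (Homo sapiens) for inhibition, read by MTT assay, with a stated time of 72 h (a lower number here means a stronger inhibitor, a higher number a weaker inhibitor), compound 3, at 77000 nM, lies within the scatter of both compound 1 and compound 2, so these three values set no order among themselves. Compound 4 `O=C(O)CCCCCCC(=O)Nc1ccc(C2=C(c3ccc(O)cc3)C3CC(S(=O)(=O)Oc4ccc5ccccc5c4)C2O3)cc1` has not yet been measured. It differs from compound 3 by naphthalen-2-yl in place of 4-(trifluoromethyl)phenyl on an oxygen. The closest evidence is the exchange between naphthalen-1-yl and 4-(trifluoromethyl)phenyl on that oxygen, a 1.6-fold higher number from compound 1 to compound 3 (0.20 log units; within the scatter). Two further steps concern the same group: a 1.7-fold higher number from compound 1 to compound 2 (0.22 log units; within the scatter) and a 1.0-fold lower number from compound 2 to compound 3 (0.02 log units; within the scatter). All three stay within the scatter, so no step beyond the scatter is expected in this assay. The estimated step is a 1.3-fold lower number from compound 3 to compound 4 (0.11 log units; within the scatter), which is no firm direction. For compound 4 the expected value is 60000 nM, with an estimated range of 33000 nM to 105000 nM.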

Compound 4, half-maximal inhibitory concentration: 58300 nM
Estimate against measurement, compound 4: 1.0-fold (0.01 log units) above, within the range that was stated.
By their numbers in this assay, from the lowest: compounds 1, 4, 3 and 2 (each within the scatter of the next).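

In this assay the exchange on the oxygen bound to the sulfonyl sulfur gives a 1.3-fold lower number from compound 3 to compound 4 (0.12 log units; within the scatter) and the two further exchanges there give a 1.4-fold lower number from compound 2 to compound 4 (0.14 log units; within the scatter) and a 1.2-fold higher number from compound 1 to compound 4 (0.08 log units; within the scatter) with all of these within the scatter. Naphthalen-2-yl thus joins naphthalen-1-yl, 4-methylphenyl and 4-(trifluoromethyl)phenyl at this oxygen without setting any order among them: neither going from one six-membered aromatic ring of carbon only to two, nor exchanging naphthalen-1-yl for naphthalen-2-yl, takes the number beyond the scatter. Nothing measured here offers an explanation for this result.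

The compounds shown leave open whether an aromatic ring containing nitrogen, such as pyridine, or an amine-bearing group on this oxygen would take the number beyond the scatter. They also leave open what a hydroxamic acid would do in place of the carboxylic acid that all four compounds share.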